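Ethoxy for (benzyloxy)amino on compound 1

The compounds below may be only part of what the source reports. "The series", "measured", "known", "first", "only" and "open" are said of these compounds alone.

For the measured compounds named here, in a functional assay on SW-620 cells (Homo sapiens) (a lower number here means a stronger inhibitor, a higher number a weaker inhibitor), compound 1 (`COc1cc(NC(C)CCCNC(=O)NOCc2ccccc2)c2ncccc2c1`) gives 20000 nM as the only numeric value so far. Compound 2 (`COc1cc(N2C(=O)NCCCC2C)c2ncccc2c1`) reads > 100000 nM in this assay and that entry is a limit of the assay, not a number. Compound 3 (`CCOC(=O)NCCCC(C)Nc1cc(OC)cc2cccnc12`) is still unmeasured. It carries ethoxy in place of (benzyloxy)amino on a carbonyl carbon and otherwise matches compound 1. Going by the values given here, no measured pair isolates this change, so the forecast has only compound 1 at 20000 nM as its anchor and remains loose. A modest move toward weaker inhibition in this assay is expected, of a size only a little beyond the usual scatter. The expected step of a 1.8-fold higher number from compound 1 to compound 3 (0.24 log units; within the scatter) is therefore small. Compound 3 is estimated at 35000 nM (expected range 12000 nM to 100000 nM).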

Compound 3, half-maximal inhibitory concentration: 45000 nM
The estimate for compound 3 lay 1.3-fold (0.11 log units) below the measured number; the range from low to high includes it.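

At the carbonyl carbon whose other neighbour is an amide-type nitrogen, ethoxy in place of (benzyloxy)amino gives a 2.3-fold higher number from compound 1 to compound 3 (0.35 log units; beyond the scatter) in this assay. For the compounds shown here, this is the first measured step at this position, and it shows that the number moves only modestly when the six-membered aromatic ring of carbon only and the hydrogen-bond donor leave together. The (benzyloxy)amino group is therefore not needed for a numeric reading, as compound 3 still gives 45000 nM.

The compounds shown do not separate the contribution of the ring from that of the nitrogen, a question that a benzyloxy or a methylamino group on the same carbonyl carbon would address. Compound 2 differs from compound 1 in more than one place and its entry is a limit of the assay, so it gives no step: the limit of > 100000 nM in this assay, at which 1 of the 3 values shown sits.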